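Phenoxy for phenyl on the longer-chain analogue

The source may hold more compounds than are shown below. What is called first, only, known or untested is meant among the compounds shown, and "the series" means these compounds.

Compound 1 `CC(C)(C)OC(=O)N1C[C@H](O)C[C@H]1COCCCCCC/C=C/c1ccc(-c2ccccc2)cc1` and compound 3 `CC(C)(C)OC(=O)N1C[C@H](O)C[C@H]1COCCCCCC/C=C/c1ccc(Oc2ccccc2)cc1` share one core and differ in a single place: phenoxy in place of phenyl on an aromatic carbon. In a functional assay on HeLa cells (Homo sapiens) for inhibition, with a stated time of 72 h (a lower number here means a stronger inhibitor, a higher number a weaker inhibitor), compound 1 gives 38500 nM, and compound 3 gives 41000 nM. That change made a step of a 1.1-fold higher number from compound 1 to compound 3 (0.03 log units; within the scatter). Compound 2 `CC(C)(C)OC(=O)N1C[C@H](O)C[C@H]1COCCCCCCCC/C=C/c1ccc(-c2ccccc2)cc1` gives 37500 nM in this assay; how the core of compound 2 differs from the core of compound 1 is not broken down here, and the two values lie within the scatter of each other. Compound 4 `CC(C)(C)OC(=O)N1C[C@H](O)C[C@H]1COCCCCCCCC/C=C/c1ccc(Oc2ccccc2)cc1` is not yet measured. Within the data shown here, it differs from compound 2 by phenoxy in place of phenyl on an aromatic carbon, the same change as the one from compound 1 to compound 3, at the same place. Among the measured compounds shown here, only one measured instance of this change exists, and it stayed within the scatter. The step expected in this assay is a 1.1-fold higher number from compound 2 to compound 4 (0.03 log units; within the scatter), resting on a 1.1-fold higher number from compound 1 to compound 3 (0.03 log units; within the scatter) alone. Compound 4 is therefore expected to give about 40000 nM in this assay, with a likely range from 25000 nM to 65000 nM.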

Compound 4, half-maximal inhibitory concentration: 41000 nM
Compound 4: the middle estimate sits 1.0-fold (0.01 log units) below what was measured; low and high end bracket the measured number.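

On the second core, phenoxy in place of phenyl gave a 1.1-fold higher number from compound 2 to compound 4 (0.04 log units; within the scatter) in this assay. Set beside the earlier instance, the change behaves alike on both cores, with no difference between the two steps beyond the scatter: the same change on two cores in this assay, a 1.1-fold higher number (0.03 log units; within the scatter) from compound 1 to compound 3 and a 1.1-fold higher number (0.04 log units; within the scatter) from compound 2 to compound 4, 1.0-fold (0.01 log units) apart, within the scatter of two such steps This shows that the swap stayed within the scatter on each of two cores, but not that it has any real effect on the number, so these two steps cannot test whether a measurable effect would carry from one core to another.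

Left open is whether a different group in the same place, such as an amine, a carboxylic acid or a benzyloxy group, would give a step beyond the scatter in this assay. Also open, on these data alone, is whether phenoxy in place of phenyl would stay within the scatter on a core with a much shorter chain.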